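Side-chain variation on the aryl ring of a pyrazolopyrimidine series

This account rests on a few compounds, and the source may have more. Where it says the series, first, only, none or still open, it means among the compounds named here.

Measured compounds in an assay for inhibition of ribosomal protein S6 kinase beta-1 variant D18H,T412E (Homo sapiens), read by a luciferase reporter and chemiluminescence, with a stated time of 3 h; on this read-out lower numbers stand for stronger inhibition and higher numbers for weaker inhibition:
compound 1 `CCc1n[nH]c2ncnc(N3CCN(c4cc(Cl)ccc4C)CC3)c12`, 6 nM
compound 2 `CCc1n[nH]c2ncnc(N3CCN(c4cc(Cl)cc(CCCN(CC)CC)c4C)CC3)c12`, 3 nM
compound 3 `CCc1n[nH]c2ncnc(N3CCN(c4cc(Cl)cc(CCCN5CCCC5)c4C)CC3)c12`, 2 nM

Compound 3 gives the lowest number of the three in this assay; the gap to compound 2 is within the scatter, while the gap to compound 1 is beyond it, so compound 3 can be read as a modest step past the unsubstituted parent.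

Compound 4 `CCc1n[nH]c2ncnc(N3CCN(c4cc(Cl)cc(NCCN(CC)CC)c4C)CC3)c12` has not yet been measured. The change from compound 3 is (2-(diethylamino)ethyl)amino in place of 3-(pyrrolidin-1-yl)propyl on an aromatic carbon.

For the measured compounds named here, the steps that bear on it are a 2.0-fold lower number from compound 1 to compound 2 (0.30 log units; within the scatter) and a 3.0-fold lower number from compound 1 to compound 3 (0.48 log units; beyond the scatter), which show that attaching either basic side chain at this position shifts the number only modestly, and a 1.5-fold lower number from compound 2 to compound 3 (0.18 log units; within the scatter), which shows that exchanging diethylamino for pyrrolidin-1-yl on the chain makes no difference beyond the scatter. Compound 4 keeps a basic amine at the chain end and brings in the diethylamino already present in compound 2, with a nitrogen linker and a shorter chain that the measured set does not cover. In this assay compound 4 is therefore expected to stay close to compound 3, with a step of a 1.5-fold higher number from compound 3 to compound 4 (0.18 log units; within the scatter), most likely no change beyond the scatter. The estimate for compound 4 is 3 nM, within 1 nM to 9 nM.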

Compound 4, half-maximal inhibitory concentration: 3 nM
For compound 4 middle estimate and measured number coincide at the digits printed; the range from low to high includes it.
By their numbers in this assay, from the lowest: compounds 3, 2, 4 and 1 (each within the scatter of the next, the first and the last beyond it).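

In this assay, (2-(diethylamino)ethyl)amino in place of 3-(diethylamino)propyl gives no change at the digits printed from compound 2 to compound 4 (within the scatter), and in place of 3-(pyrrolidin-1-yl)propyl, which has the same heavy-atom count, it gives a 1.5-fold higher number from compound 3 to compound 4 (0.18 log units; within the scatter), so this aromatic carbon also tolerates a chain attached through nitrogen. Against hydrogen the same chain gives a 2.0-fold lower number from compound 1 to compound 4 (0.30 log units; within the scatter), so compound 4 does not share the separation from compound 1 that compound 3 shows. No supporting data on this result are available to account for it.

The attaching nitrogen and the shorter chain change together between compound 2 and compound 4, so neither can be read alone. Also open, from the compounds shown here alone, is how a chain ending in a carboxylic acid or a hydroxyl instead of an amine would read at this position.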